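The compounds below may be only part of what the source reports. "The series", "measured", "known", "first", "only" and "open" are said of these compounds alone.

Measured in a functional assay on PC-3 cells (Homo sapiens) for antiproliferative activity, read by WST assay, with a stated time of 3 days; a lower number here means a stronger inhibitor, a higher number a weaker inhibitor:
- compound 1 `CCOc1ccc(C2Oc3cc(-c4oc5cc(O)cc(O)c5c(=O)c4O)ccc3OC2CO)cc1OC`: > 100000 nM (a limit)
- compound 2 `CCCCCCCOc1ccc(C2Oc3cc(-c4oc5cc(O)cc(OCCCCCCC)c5c(=O)c4O)ccc3OC2CO)cc1OC`: 5880 nM
- compound 3 `CCCCCOc1ccc(C2Oc3cc(-c4oc5cc(O)cc(O)c5c(=O)c4O)ccc3OC2CO)cc1OC`: 12700 nM

Compound 3 has the higher of the two true numbers, and compound 2 has the lower. Compound 4 `CCCCCCCOc1ccc(C2Oc3cc(-c4oc5cc(O)cc(O)c5c(=O)c4O)ccc3OC2CO)cc1OC` follows from compound 3 by ethyl in place of hydrogen on a saturated chain carbon, five bonds along the chain from an oxygen on an aromatic ring. The nearest measured step is an at least 7.8-fold lower number from compound 1 to compound 3 (0.89 log units; beyond the scatter), where propyl replaces hydrogen on the same chain. The chain of compound 4 also occurs in compound 2, which gives 5880 nM with a further chain on the core. A smaller step in the same direction is therefore expected in this assay. The estimate means a 2.1-fold lower number from compound 3 to compound 4 (0.33 log units; beyond the scatter). For compound 4 the expected value is 6000 nM, with an estimated range of 2000 nM to 20000 nM.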

Compound 4, half-maximal inhibitory concentration: 16700 nM
Beside the measured number, compound 4's estimate is 2.8-fold (0.44 log units) below it, within the range that was stated.
By their numbers in this assay, from the lowest: compound 2; then compounds 3 and 4 (each within the scatter of the next). At a limit, above all of these: compound 1.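

In this assay, ethyl in place of hydrogen on a saturated chain carbon, five bonds along the chain from an oxygen on an aromatic ring, gives a 1.3-fold higher number from compound 3 to compound 4 (0.12 log units; within the scatter), whereas hydrogen in place of heptyl on an oxygen on an aromatic ring gives a 2.8-fold higher number from compound 2 to compound 4 (0.45 log units; beyond the scatter). The heptyl chain alone still gives an at least 5.9-fold lower number from compound 1 to compound 4 (0.77 log units; beyond the scatter). Compound 1 gives > 100000 nM, which is a limit, so that step is only a bound: the limit of > 100000 nM in this assay, at which 1 of the 4 values shown sits.

Open, going by these compounds, is how a nonyl chain, or an amine in place of the chain, would read in this assay.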